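The source may hold more compounds than are shown below. What is called first, only, known or untested is meant among the compounds shown, and "the series" means these compounds.

Measured compounds:
compound 1 `Cc1nc2cc(OC[C@H](O)CN3CCN(Cc4noc(-c5ccc(C(C)(C)C)cc5)n4)CC3)ccc2s1` — 180 nM
compound 2 `Cc1nc2cc(OC[C@H](O)CN3CCN(Cc4nnc(-c5ccc(C(F)(F)F)cc5)o4)CC3)ccc2s1` — 4800 nM
compound 3 `Cc1nc2cc(OC[C@H](O)CN3CCN(Cc4coc(-c5ccc(C(F)(F)F)cc5)n4)CC3)ccc2s1` — 11000 nM

In a functional assay on mitochondria from heart for inhibition of peroxisomal acyl-coenzyme A oxidase 1 (Rattus norvegicus) (on this read-out higher numbers stand for weaker inhibition and lower numbers for stronger inhibition), compound 1 gives the lowest of the three numbers. Among the measured compounds shown here, compound 2 and compound 3 each differ from compound 1 in more than one place, so no single step among the measured compounds can be isolated; their values simply show that compound 1 stands well apart from both, with the gap to compound 3 the wider of the two.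

Compound 4 `Cc1nc2cc(OC[C@H](O)CN3CCN(Cc4noc(-c5ccc(Cl)c(Cl)c5)n4)CC3)ccc2s1` has not been measured. It is built from compound 1 by one change: 3,4-dichlorophenyl in place of 4-(tert-butyl)phenyl on an aromatic carbon. The five-membered ring and the rest of the shared core are kept as in compound 1.

For the measured compounds named here, nothing among the measured compounds tracks this particular change, so the expectation rests on compound 1 alone. A modest shift in this assay toward a higher number, or none beyond the scatter, is expected, with the step from compound 1 to compound 4 put at a 2.2-fold higher number from compound 1 to compound 4 (0.35 log units; beyond the scatter). Compound 4 is estimated at 400 nM, within a range of 120 nM to 1500 nM.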

Compound 4, half-maximal inhibitory concentration: 550 nM
Compound 4: middle estimate off by 1.4-fold (0.14 log units), on the low side; measured number inside the range.
By their numbers in this assay, from the lowest: compound 1; then compound 4; then compound 2; then compound 3.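

In this assay, among the compounds shown here, the step at this aryl position is the only single-place comparison: a 3.1-fold higher number from compound 1 to compound 4 (0.49 log units; beyond the scatter) with 3,4-dichlorophenyl in place of 4-(tert-butyl)phenyl. The position therefore responds to this exchange, but only modestly, and compound 4 at 550 nM keeps measurable inhibition with the 4-(tert-butyl)phenyl group gone. No supporting data on the compounds bear on what lies behind this step.

Open, on these data alone, is whether a phenyl ring with a single chlorine, a methoxy group or an aminomethyl group would fall nearer compound 1 or compound 4. Also open, as far as these compounds go, is whether the same exchange would give a step of similar size on the different five-membered rings of compound 2 and compound 3, which carry another aryl group.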